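The source may hold more compounds than are shown below. What is called first, only, known or untested is meant among the compounds shown, and "the series" means these compounds.

Two compounds have been run through a functional assay on KYSE-450 cells (Homo sapiens) for inhibition, read by MTT assay, with a stated time of 48 h; on this read-out lower numbers stand for stronger inhibition and higher numbers for weaker inhibition. Compound 1, `C/C=C/C(=O)N(Cc1cc(OC)c(OC)c(OC)c1)c1ccc(OC)c(O)c1`, gives 9160 nM. Compound 2, `C=C(C)C(=O)N(Cc1ccc(OC)c(O)c1)c1cc(OC)c(OC)c(OC)c1`, gives 200 nM. Of the two numbers, compound 2 has the lower one, and the distance from compound 2 up to compound 1 lies well beyond the ordinary scatter of repeated measurements. Compound 1 and compound 2 differ in more than one place at once, so their two values alone say nothing about any single part of the structure.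

Compound 3, `C/C=C/C(=O)N(Cc1ccc(OC)c(O)c1)c1cc(OC)c(OC)c(OC)c1`, has not yet been measured. It keeps the whole of compound 2 apart from one change at the carbonyl carbon of the amide: prop-1-en-1-yl in place of 1-methylethenyl on a carbonyl carbon. Both groups are small hydrocarbon pieces of the same size, each carrying one double bond next to the carbonyl, so the shape of the acyl piece shifts while nothing else moves.

Going by the values given here, no measured pair shows this exact change, so its effect is a guess. Compound 3 is expected to land a little weaker than compound 2, with the step of a 2.5-fold higher number from compound 2 to compound 3 (0.40 log units; beyond the scatter), a move that may sit near the edge of the scatter rather than clearly beyond it. Compound 3 is therefore estimated at 500 nM in this assay, with a plausible range from 150 nM to 2000 nM.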

Compound 3, half-maximal inhibitory concentration: 67 nM
Beside the measured number, compound 3's estimate is 7.5-fold (0.87 log units) above it; measured number below the stated range.
By their numbers in this assay, from the lowest: compound 3; then compound 2; then compound 1.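

Going by these compounds alone, until this pair, no two measured compounds differed in one place only, so no single part of the structure could be judged on its own. Putting prop-1-en-1-yl in place of 1-methylethenyl on a carbonyl carbon gives, in this assay, a 3.0-fold lower number from compound 2 to compound 3 (0.47 log units; beyond the scatter), so this position responds even when the same atoms are only joined differently, although the step is a modest one. Nothing available explains why the number moves in this direction, and no cause can be given for it.

The compounds shown say nothing about how far this position tolerates other pieces on the carbonyl carbon: a saturated propyl chain, a longer chain such as pent-1-en-1-yl, a cyclopropyl ring or an amine could each keep the lower number or lose it. Within the data shown here, it also stays open whether the same swap would give a similar step on a different core, such as the one in compound 1, where the groups on the two aromatic rings are arranged differently.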